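This account rests on a few compounds, and the source may have more. Where it says the series, first, only, none or still open, it means among the compounds named here.

The measured compounds:

compound 1, `COc1cc(NC(C)CCCNC(=O)NCCO)c2ncccc2c1` — "not determined" (no result reported)
compound 2, `COc1cc(NC(C)CCCNC(=O)NNC(=O)/C=C/c2ccc(OC)c(OC)c2)c2ncccc2c1` — 37000 nM
compound 3, `COc1cc(NC(C)CCCNC(=O)NNC(=O)N(CCO)CCO)c2ncccc2c1` — 178000 nM

In an ADME assay on L6 cells (Rattus norvegicus) for cytotoxicity, read by resazurin assay, with a stated time of 70 h (a higher number here means a weaker inhibitor, a lower number a stronger inhibitor), compound 2 gives 37000 nM. In this assay compound 3 gives 178000 nM. For compound 1 no number exists in this assay: the entry reads "not determined" (no result reported), so compound 1 cannot be placed against the other two.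

Going by the values given here, the single measured step is a 4.8-fold higher number from compound 2 to compound 3 (0.68 log units; beyond the scatter), where bis(2-hydroxyethyl)amino stands in place of 2-(3,4-dimethoxyphenyl)ethenyl on a carbonyl carbon.

Compound 4, `COc1cc(NC(C)CCCNC(=O)NNC(=O)Nc2ccc(Br)cc2)c2ncccc2c1`, derives from compound 1 by one change:

((4-bromophenyl)carbamoyl)amino in place of 2-hydroxyethyl on an amide-type nitrogen

Among the compounds with values here, no measured step touches this change, and compound 1 itself has no value, so no step size can be read off for this assay. What the data do show is that the two measured compounds lie apart by one modest step, and that compound 4, like compound 2, carries a six-membered aromatic ring of carbon only at the end of the chain, whereas compound 3 does not.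

On that slim basis compound 4 is expected to fall in this assay near 50000 nM, with a range of 15000 nM to 160000 nM.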

Compound 4, half-maximal inhibitory concentration: 38700 nM
The estimate for compound 4 lay 1.3-fold (0.11 log units) above the measured number; low and high end bracket the measured number.
By their numbers in this assay, from the lowest: compounds 2 and 4 (each within the scatter of the next); then compound 3.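

In this assay the new compound gives a second comparison with compound 3: (4-bromophenyl)amino in place of bis(2-hydroxyethyl)amino on a carbonyl carbon gives a 4.6-fold lower number from compound 3 to compound 4 (0.66 log units; beyond the scatter) and so matches the size of the earlier step, in the opposite direction. Among these three compounds, the two that end in a six-membered aromatic ring of carbon only now both lie below compound 3, and none of the three goes against this. The step between those two groups, (4-bromophenyl)amino in place of 2-(3,4-dimethoxyphenyl)ethenyl, is a 1.0-fold higher number from compound 2 to compound 4 (0.02 log units; within the scatter) and so does not separate them, and no measurement shown accounts for any of these differences.

Compound 1 has no number, so the change from 2-hydroxyethyl to ((4-bromophenyl)carbamoyl)amino cannot be read at all. Going by these compounds, it also remains open whether the bromine plays any part or the ring alone goes with the lower numbers, a question that a plain phenylamino or a cyclohexylamino group on the same carbonyl carbon would address.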